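A few compounds are considered here, and "the series" means these few. Any claim that something is new, unique, unknown or untested is made for them only; others in the source may bear on it.

Notes on the series, read out in a functional assay on RAW264.7 cells (Mus musculus) for inhibition; on this read-out higher numbers stand for weaker inhibition and lower numbers for stronger inhibition. Compound 3 `COc1cc(/C=C/C(=O)CC(=O)/C=C/c2ccc(OC(=O)C(C)c3ccc(CC(C)C)cc3)c(OC)c2)ccc1O` gives > 30000 nM, which is a limit and not a number. Compound 1 `COc1cc(/C=C/C(=O)CC(=O)/C=C/c2ccc(OC(=O)C(C)c3ccc(C(=O)c4ccccc4)cc3)c(OC)c2)ccc1OC(=O)C(C)c1ccc(C(=O)c2ccccc2)cc1` gives > 30000 nM, also a limit. Compound 2 `COc1ccc2cc([C@@H](C)C(=O)Oc3ccc(/C=C/C(=O)CC(=O)/C=C/c4ccc(OC(=O)[C@H](C)c5ccc6cc(OC)ccc6c5)c(OC)c4)cc3OC)ccc2c1` gives > 30000 nM, again a limit. All three compounds therefore stand together: the limit of > 30000 nM in this assay, at which 3 of the 3 values shown sit. Compound 4 `COc1cc(/C=C/C(=O)CC(=O)/C=C/c2ccc(OC(=O)C(C)c3ccc(C(=O)c4ccccc4)cc3)c(OC)c2)ccc1O` has benzoyl in place of isobutyl on an aromatic carbon, para to a large group: benzoyl in place of isobutyl on an aromatic carbon. Benzoyl also occurs in compound 1, and its value of > 30000 nM is a limit. In this assay, the estimated step of a number no higher from compound 3 to compound 4 (the limit leaves the size open) is expected to stay within the scatter, with no direction favoured. For compound 4 the expected value is 30000 nM, with an estimated range of 10000 nM to 60000 nM.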

Compound 4, half-maximal inhibitory concentration: 8980 nM
The estimate for compound 4 lay 3.3-fold (0.52 log units) above the measured number, outside the stated range (below it).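

Benzoyl in place of isobutyl gives an at least 3.3-fold lower number from compound 3 to compound 4 (0.52 log units; beyond the scatter), so in this assay this aromatic carbon, para to a large group, responds to the change. Compound 4 is the one compound off the shared limit: the limit of > 30000 nM in this assay, at which 3 of the 4 values shown sit.
Compound 1 also carries benzoyl and gives > 30000 nM, which is a limit.

On these data alone, the full size of the step stays open, as compound 3 has only a limit. Also open, as far as these compounds go, is whether a plain phenyl, an acetyl or an amine on this carbon would match compound 4.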